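The compounds below may be only part of what the source reports. "The series", "measured", "known", "first", "only" and "open" are said of these compounds alone.

Measured compounds:
compound 1 `COc1ccc2c(c1)C(n1ccccc1=O)=CC(C)(C)O2` — 6.55
compound 2 `CC1(C)C=C(n2ccccc2=O)c2cc(C(=O)c3ccccc3)ccc2O1` — 6.61
compound 3 `Cc1ccccc1C(=O)c1ccc2c(c1)C(n1ccccc1=O)=CC(C)(C)O2` — 6.83

In a functional assay (aorta) with Rattus norvegicus as the target (on this read-out higher numbers stand for higher potency (the scale is a negative logarithm) and lower numbers for lower potency), compound 1 gives 6.55, the lowest of the three numbers, though its gaps to compound 2 and to compound 3 are both within the scatter, so no order among them can be claimed. Compound 2 gives 6.61 after the change a number 0.06 log units higher from compound 1 to compound 2 (within the scatter), and compound 3 gives 6.83 after the change a number 0.28 log units higher from compound 1 to compound 3 (within the scatter); the two benzoyl-type compounds differ from each other only by a number 0.22 log units higher from compound 2 to compound 3 (within the scatter).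

The unmeasured compound 4 `CC1(C)C=C(n2ccccc2=O)c2cc(C=O)ccc2O1` differs from compound 1 by formyl in place of methoxy on an aromatic carbon. Going by the values given here, the steps that bear on it are those from compound 1 to compound 2 and from compound 1 to compound 3, in which methoxy likewise gave way to a group carrying a carbonyl, and both stayed within the scatter. Formyl is a smaller group than either benzoyl or (2-methylphenyl)carbonyl, and no measured step tests that size directly, so the expectation rests only on the replacement of methoxy. On that basis compound 4 is expected to show a step of a number 0.05 log units lower from compound 1 to compound 4 (within the scatter), that is, no change beyond the scatter, and its value in this assay is estimated at 6.5, between 6 and 7.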

Compound 4, logarithm of the reciprocal of the active concentration, log(1/C): 6.91
Compound 4: the middle estimate sits 0.41 log units below what was measured; measured number inside the range.
By their numbers in this assay, from the lowest: compounds 1, 2, 3 and 4 (each within the scatter of the next, the first and the last beyond it).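

Formyl in place of methoxy on this aromatic carbon gives the first step at the position to pass the scatter in this assay (a modest one: a number 0.36 log units higher from compound 1 to compound 4 (beyond the scatter)), although the two groups have the same counts of heavy atoms and hydrogen-bond acceptors. With hydrogen in place of the aryl group on the carbonyl carbon, both a number 0.08 log units higher from compound 3 to compound 4 (within the scatter) and a number 0.30 log units higher from compound 2 to compound 4 (within the scatter) stay within the scatter, so these three carbonyl compounds cannot be separated by what the carbonyl carries. Nothing measured on these compounds explains the step from methoxy to formyl.

The compounds shown leave open whether that step belongs to the carbonyl itself or to formyl alone. They also leave open how an acetyl group, a nitrile or a carboxylic acid would read at this aromatic carbon.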